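Trifluoromethyl in place of benzoyl on the shared core

A few compounds are considered here, and "the series" means these few. Any claim that something is new, unique, unknown or untested is made for them only; others in the source may bear on it.

All values below come from a functional assay (trachea) with Rattus norvegicus as the target; on this read-out lower numbers stand for lower potency and higher numbers for higher potency (the scale is a negative logarithm).
Compound 1 `CC1(C)C=C(n2ccccc2=O)c2cc(C(=O)c3ccccc3)ccc2O1` gives 6.21.
Compound 2 `CC1(C)C=C(n2ccccc2=O)c2cc(OC(=O)Nc3ccccc3)ccc2O1` gives 4.89.
Compound 3 `CC1(C)C=C(n2ccccc2=O)c2cc(OC(=O)Nc3ccc(C(F)(F)F)cc3)ccc2O1` gives 4.54.

Compound 1 stands highest of the three numbers in this assay; compound 2 and compound 3, which carry carbamate groups at the same position of the core, both sit beyond the scatter below it. Among the measured compounds shown here, the only measured single-point step is a number 0.35 log units lower from compound 2 to compound 3 (beyond the scatter), where the trifluoromethyl enters on the distal phenyl of the carbamate, not on the core itself, so it bears only loosely on the case at hand.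

Compound 4 `CC1(C)C=C(n2ccccc2=O)c2cc(C(F)(F)F)ccc2O1` differs from compound 1 as follows: trifluoromethyl in place of benzoyl on an aromatic carbon. For the measured compounds named here, no measured compound carries trifluoromethyl on the core, and no measured pair removes the benzoyl alone. Since the two compounds lacking benzoyl both fall well short of compound 1, a drop is expected for compound 4, of the order of a number 0.91 log units lower from compound 1 to compound 4 (beyond the scatter). In this assay compound 4 is estimated at 5.3, within 4.6 to 6.1.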

Compound 4, logarithm of the reciprocal of the active concentration, log(1/C): 7.37
Estimate against measurement, compound 4: 2.07 log units below, and the stated range ends below it.
By their numbers in this assay, from the lowest: compound 3; then compound 2; then compound 1; then compound 4.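

In this assay, the exchange of benzoyl for trifluoromethyl on this aromatic carbon gives a number 1.16 log units higher from compound 1 to compound 4 (beyond the scatter) and marks a large step. The read-out at this position therefore does not depend on benzoyl: the six-membered aromatic ring and the hydrogen-bond acceptor both leave, and the number still rises. A much smaller group, with four heavy atoms against eight and no ring, is enough here for a number above that of compound 1.

Among the compounds shown here, the single step cannot separate the loss of benzoyl from the arrival of trifluoromethyl, and a plain hydrogen, a chlorine or a nitrile on the same carbon would help to tell these apart. Nothing shown gives a measured property or other data that would explain the rise.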